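This account rests on a few compounds, and the source may have more. Where it says the series, first, only, none or still open, it means among the compounds named here.

Compound 2 `COc1ccc(-c2[nH]c3ccc(OC)cc3c2/C=C(\C#N)S(=O)(=O)c2ccccc2)cc1` was tested in an ADME assay on CRL-7065 cells (Homo sapiens) for cytotoxicity, read by MTT assay, with a stated time of 96 h; on this read-out higher numbers stand for an effect only at larger amounts of compound and lower numbers for an effect already at smaller amounts. In this assay compound 2 gives > 100000 nM, which is a limit of the assay and not a measured number. Compound 1 `COc1ccc(-c2[nH]c3ccccc3c2/C=C(\C#N)S(=O)(=O)c2ccccc2)cc1` differs from compound 2 only by a methoxy group on an aromatic carbon. In this assay compound 1 gives > 100000 nM, again a limit. The step that the two limits leave unreadable from compound 1 to compound 2 therefore cannot be read. Compound 3 `CC(=O)/C(=C/c1c(-c2ccccc2)[nH]c2ccccc12)C(=O)c1ccccc1` gives > 100000 nM, also a limit, so that (the limit of > 100000 nM in this assay, at which 3 of the 3 values shown sit). Compound 4 `COc1ccc2[nH]c(-c3ccccc3)c(/C=C(\C#N)S(=O)(=O)c3ccccc3)c2c1` has not yet been measured; it differs from compound 2 by hydrogen in place of methoxy on an aromatic carbon. With no readable step available, the step that the limit leaves unreadable from compound 2 to compound 4 is expected to be none beyond the scatter. Compound 4 is expected to give 150000 nM, within 100000 nM and 300000 nM, most likely reported again only as a limit.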

Compound 4, half-maximal effective concentration: 11000 nM
Compound 4: the middle estimate sits 14-fold (1.13 log units) above what was measured; the whole stated range lies above it.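

In this assay, going by these compounds alone, going from 4-methoxyphenyl to phenyl gives an at least 9.0-fold lower number from compound 2 to compound 4 (0.95 log units; beyond the scatter), so this methoxy is the first place where a change can be read, and its loss brings the effect to smaller amounts of compound. The earlier step cannot be read, and compound 4 is the only compound here with a measured number rather than a limit: the limit of > 100000 nM in this assay, at which 3 of the 4 values shown sit.

As far as these compounds go, it remains open what an amine, a carboxylic acid or a longer chain would do at this place. From the compounds shown here alone, it also remains open whether the methoxy still on the core of compound 4 plays any part in this number.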